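Compound 3 to compound 4: side chain on the amide

The source may hold more compounds than are shown below. What is called first, only, known or untested is meant among the compounds shown, and "the series" means these compounds.

Values in an ADME assay on L02 cells (Homo sapiens) for antiproliferative activity, read by MTT assay, with a stated time of 48 h (on this read-out higher numbers stand for weaker inhibition and lower numbers for stronger inhibition), for the measured compounds
compound 1 `CCn1c(C(=O)NCCN)ccc1C(CC)(CC)c1ccc(OCCC(O)(CC)CC)c(C)c1` gives 2940 nM as a number
compound 2 `CCOc1ccc(NC(=O)c2ccc(C(CC)(CC)c3ccc(OCCC(O)(CC)CC)c(C)c3)n2CC)cc1` gives > 50000 nM as a limit of the assay
compound 3 `CCn1c(C(=O)NC(C)C(=O)O)ccc1C(CC)(CC)c1ccc(OCCC(O)(CC)CC)c(C)c1` gives 4040 nM as a number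

Compound 3 stands level with compound 1 (a 1.4-fold higher number from compound 1 to compound 3 (0.14 log units; within the scatter)) and well apart from compound 2 (an at least 12-fold lower number from compound 2 to compound 3 (1.09 log units; beyond the scatter)). Compound 4 `CCC(C)C(CO)NC(=O)c1ccc(C(CC)(CC)c2ccc(OCCC(O)(CC)CC)c(C)c2)n1CC` differs from compound 3 as follows (1-(hydroxymethyl)-2-methylbutyl in place of 1-carboxyethyl on an amide-type nitrogen). Its entering group has no ring, as with the open-chain groups of compound 1 and compound 3 (a 1.4-fold higher number from compound 1 to compound 3 (0.14 log units; within the scatter)). Only the ring-bearing group of compound 2 gave a large step (an at least 17-fold higher number from compound 1 to compound 2 (1.23 log units; beyond the scatter)). In this assay the expected change is a slight lean to a higher number, estimated as a 1.7-fold higher number from compound 3 to compound 4 (0.24 log units; within the scatter). For compound 4 the estimated value is 7000 nM (expected range 2500 nM to 25000 nM).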

Compound 4, half-maximal inhibitory concentration: > 50000 nM
Compound 4: no number, only a limit (the forecaster's own chance of this, stated with the estimate: 15%); at least 7.1-fold (0.85 log units) between middle value and limit.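

In this assay, a large step on the amide-type nitrogen no longer belongs only to the ring-bearing group of compound 2: 1-(hydroxymethyl)-2-methylbutyl, which has no ring, gives an at least 12-fold higher number from compound 3 to compound 4 (1.09 log units; beyond the scatter) and an at least 17-fold higher number from compound 1 to compound 4 (1.23 log units; beyond the scatter). The value of compound 4 is a limit of the assay, not a number. The step between compound 2 and compound 4 cannot be read: the limit of > 50000 nM in this assay, at which 2 of the 4 values shown sit.

Going by these compounds, it remains open whether the step follows the change from carboxylic acid to hydroxymethyl or the longer branched chain. A 1-carboxy-2-methylbutyl group on the same nitrogen would separate these two changes.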